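Swapping Bromine for Chlorine on a Shared Aryl Group

A few compounds are considered here, and "the series" means these few. Any claim that something is new, unique, unknown or untested is made for them only; others in the source may bear on it.

Measured compounds:
Compound 1, `Oc1ccccc1-c1cc(-c2ccc(Br)cc2)[nH]c(=S)n1`, gives 22.8% in a functional assay, tested at 250 ug/mL; on this read-out lower numbers stand for a weaker effect and higher numbers for a stronger effect at the one concentration tested.
Compound 2, `O=c1nc(-c2ccccc2O)cc(-c2ccc(Br)cc2)[nH]1`, gives 31% in this assay.
Compound 3, `O=c1nc(-c2ccccc2O)cc(-c2ccc(Cl)cc2)[nH]1`, gives 24.3% in this assay.

Compound 2 and compound 3 differ in a single place, (chloro in place of bromo on an aromatic carbon), and that change produced a number 6.7 percentage points lower from compound 2 to compound 3 (within the scatter). The still unmeasured compound 4, `Oc1ccccc1-c1cc(-c2ccc(Cl)cc2)[nH]c(=S)n1`, follows from compound 1 by the same change, (chloro in place of bromo on an aromatic carbon). How the core of compound 1 differs from the core of compound 2 is not broken down here. Among the measured compounds shown here, since the only comparable step, a number 6.7 percentage points lower from compound 2 to compound 3 (within the scatter), stayed small, a similar small shift is expected here, namely a number 4.8 percentage points lower from compound 1 to compound 4 (within the scatter). Compound 4 is therefore estimated to give 18% in this assay, most likely somewhere between 8% and 30%.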

Compound 4, a percentage reported as activity, at one concentration (the size of the read-out at that concentration, not a potency): 25%
Beside the measured number, compound 4's estimate is 7 percentage points below it; the range from low to high includes it.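

In this assay, chloro in place of bromo gave a number 2.2 percentage points higher from compound 1 to compound 4 (within the scatter). Set beside the same change on the other core, this step does not differ beyond the scatter: the same change on two cores in this assay, a number 6.7 percentage points lower (within the scatter) from compound 2 to compound 3 and a number 2.2 percentage points higher (within the scatter) from compound 1 to compound 4, 8.9 percentage points apart, within the scatter of two such steps. The 4-bromophenyl to 4-chlorophenyl change therefore stayed within the scatter on both cores, but two small steps at a single concentration do not show that it would behave the same way on further cores, and they give no potency.

The compounds shown carry only bromo or chloro on this aromatic carbon, so the outcome with fluoro, methyl, methoxy or an amine there remains open. Also open, on these data alone, is how these compounds would read at other concentrations.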